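The source may report more compounds than this note shows. Statements on the series, on what has been measured and on what is new or still open speak of the compounds shown alone.

Compound 1 `N=C(N)c1ccc(-c2ccc(-c3ccc([N+](=O)[O-])cc3)o2)cc1` | 3200 nM
Compound 2 `N=C(N)c1ccc(-c2ccc(-c3cccc(F)c3)o2)cc1` | 2600 nM

Both numbers come from a functional assay on MCF7 cells (Homo sapiens) for cytotoxicity, read by MTT assay, with a stated time of 96 h (a higher number here means a weaker inhibitor, a lower number a stronger inhibitor), and lie within the usual scatter of each other, so compound 2 cannot be ranked against compound 1. Compound 3 `N=C(N)c1ccc(-c2ccc(-c3ccc(Br)cc3)o2)cc1` carries 4-bromophenyl in place of 3-fluorophenyl on an aromatic carbon of a five-membered aromatic ring with 1 oxygen (4-bromophenyl in place of 3-fluorophenyl on an aromatic carbon). For the measured compounds named here, no measured step between two compounds differing in one place is available as a guide. With compound 2 at 2600 nM and compound 1 at 3200 nM as the only reference points, no change beyond the scatter is expected in this assay, and no clear direction is expected either. The expected step (a 1.1-fold lower number from compound 2 to compound 3 (0.03 log units; within the scatter)) is small. For compound 3 the estimated half-maximal inhibitory concentration is 2400 nM with an expected range from 1000 nM to 5500 nM around it.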

Compound 3, half-maximal inhibitory concentration: 2600 nM
For compound 3 the middle estimate is 1.1-fold (0.03 log units) below the measured one; the measured number falls inside the stated range.
By their numbers in this assay, from the lowest: compounds 2, 3 and 1 (each within the scatter of the next).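

At this aromatic carbon of the five-membered aromatic ring with 1 oxygen, this assay now offers steps between compounds that differ in one place: 4-bromophenyl in place of 3-fluorophenyl (no change at the digits printed from compound 2 to compound 3 (within the scatter)) and bromo in place of nitro on an aromatic carbon (a 1.2-fold lower number from compound 1 to compound 3 (0.09 log units; within the scatter)). Both steps lie within the scatter, so the 3-fluorophenyl, 4-bromophenyl and nitro-bearing phenyl groups cannot be told apart at this position, a statement that holds for these compounds only. Nothing measured here offers an explanation for this result.

The step from compound 2 to compound 3 changes both the halogen and its place on the phenyl ring, so the two cannot be separated. Going by these compounds, it also remains open whether an amine or a carboxylic acid on that phenyl ring, or a longer alkyl chain in place of it, would give a step beyond the scatter.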